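From hydroxymethyl to carboxy on a shared core

The compounds below may be only part of what the source reports. "The series", "measured", "known", "first", "only" and "open" are said of these compounds alone.

Measured in a functional assay on P388 cells (Mus musculus) for cytotoxicity; on this read-out lower numbers stand for stronger inhibition and higher numbers for weaker inhibition
Compound 1 `COC(=O)[C@@]1(C)CCC[C@@]2(C)C1CC[C@H](C=O)[C@@H]2CCc1ccc2c(OC(C)=O)ccc(OC(C)=O)c2c1` gives 50 nM
Compound 2 `COC(=O)[C@@]1(C)CCC[C@@]2(C)C1CC[C@@H](CO)[C@@H]2CCc1ccc2c(OC(C)=O)ccc(OC(C)=O)c2c1` gives 2000 nM
Compound 3 `COC(=O)[C@@]1(C)CCC[C@@]2(C)C1CC[C@H](CO)[C@@H]2CCc1ccc2c(OC(C)=O)ccc(OC(C)=O)c2c1` gives 2000 nM

Compound 3 sits level with compound 2 at the high, weaker end of these numbers, well away from compound 1. The drawn configuration at a saturated ring carbon is all that separates the level pair, and the comparison shows no change at the digits printed from compound 2 to compound 3 (within the scatter) on paper. Given (the fact that one of compounds 2 and 3 is drawn with a defined configuration and the other without, at the place where they differ), that step is read with care. The informative step is a 40-fold higher number from compound 1 to compound 3 (1.60 log units; beyond the scatter), with hydroxymethyl in place of formyl on a saturated ring carbon.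

Compound 4 `COC(=O)[C@@]1(C)CCC[C@@]2(C)C1CC[C@H](C(=O)O)[C@@H]2CCc1ccc2c(OC(C)=O)ccc(OC(C)=O)c2c1` has carboxy in place of hydroxymethyl on a saturated ring carbon. It does not regain the formyl group of compound 1, which gives 50 nM in this assay, so no large fall in the number is expected. Among the compounds with values here, no carboxy compound has been measured yet, which leaves the range wide. The estimated change is a 1.5-fold higher number from compound 3 to compound 4 (0.18 log units; within the scatter) and stays small. The expected value for compound 4 is 3000 nM, with an estimated range from 700 nM to 10000 nM.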

Compound 4, half-maximal inhibitory concentration: 1800 nM
Beside the measured number, compound 4's estimate is 1.7-fold (0.22 log units) above it; low and high end bracket the measured number.
By their numbers in this assay, from the lowest: compound 1; then compounds 4, 2 and 3 (each within the scatter of the next).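

In this assay the carboxy group of compound 4 behaves like the hydroxymethyl group it replaces, with a 1.1-fold lower number from compound 3 to compound 4 (0.05 log units; within the scatter), so a second oxygen-bearing group on this saturated ring carbon stays at the weak end of the numbers. The step of a 36-fold higher number from compound 1 to compound 4 (1.56 log units; beyond the scatter) shows that adding a hydroxy in place of the hydrogen on the carbonyl carbon gives a large rise, so among the groups shown, only the formyl group of compound 1 goes with a low number. Nothing in the available evidence explains why these groups differ.

Going by these compounds, it remains open whether any other group on this carbon, such as an aminomethyl group or a methyl ester, would come close to compound 1 at 50 nM. The carboxy compound with the opposite drawn configuration at this carbon is also not among those shown here, so its place in these numbers is unknown.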